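The source may hold more compounds than are shown below. What is called first, only, known or untested is meant among the compounds shown, and "the series" means these compounds.

Working notes on the series, all read in a functional assay on HCT-116 cells (Homo sapiens) for inhibition, read by sulforhodamine B assay, with a stated time of 48 h, tested at 50 uM; on this read-out higher numbers stand for more inhibition of growth at the one concentration tested and lower numbers for less inhibition of growth. For the measured compounds named here, compound 1 `COc1ccc([C@@H]2C/C(=N/OCc3cn(-c4ccc(C(=O)c5ccccc5)cc4)nn3)c3cc(CC=C(C)C)c(OC)cc3O2)cc1` gives 52% and compound 2 `COc1ccc([C@@H]2C/C(=N/OCc3cn(-c4ccc(C(N)=O)cc4)nn3)c3cc(CC=C(C)C)c(OC)cc3O2)cc1` gives 100%, so compound 2 holds the higher of the only two numbers so far. Next in line is compound 3 `COc1ccc([C@@H]2C/C(=N/OCc3cn(-c4ccc(NC(C)=O)cc4)nn3)c3cc(CC=C(C)C)c(OC)cc3O2)cc1`, which keeps the shared core and differs from compound 2 in one group: acetamido in place of carbamoyl on an aromatic carbon. In words, acetamido replaces carbamoyl on an aromatic carbon, para to a large group. Going by the values given here, only one measured step bears on this, and it bears indirectly: a number 48 percentage points higher from compound 1 to compound 2 (beyond the scatter), a large step, with amino in place of phenyl on a carbonyl carbon. Among the compounds with values here, it shows that the read-out can move strongly with a change in this group, but no measured compound carries acetamido. Compound 2 at 100% leaves little room for a gain, so any step beyond the scatter should point downward. The expected change is a number 25 percentage points lower from compound 2 to compound 3 (beyond the scatter), smaller than the measured step. For compound 3 the estimate is 75%, with an expected range of 45% to 100%.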

Compound 3, percent growth inhibition at one concentration: 6%
For compound 3 the middle estimate is 69 percentage points above the measured one; the measured number lies below the stated range.
By their numbers in this assay, from the lowest: compound 3; then compound 1; then compound 2.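

In this assay, acetamido in place of carbamoyl on the same aromatic carbon, para to a large group, gives a number 94 percentage points lower from compound 2 to compound 3 (beyond the scatter) and so shows that the read-out at this position can fall sharply even when the group changes only modestly. Acetamido also compares poorly with benzoyl, with a number 46 percentage points lower from compound 1 to compound 3 (beyond the scatter) in the same assay, so across these three compounds the read-out does not follow the size of the group: the largest group, benzoyl, stands between carbamoyl and acetamido. In compounds 1 and 2 a carbonyl carbon sits on the ring, whereas in compound 3 a nitrogen does, and no measurement at hand accounts for the loss.

Carbamoyl and acetamido differ both in the atom attached to the ring and in the extra carbon, so the compounds shown do not separate these two changes. A simple amine or a carboxylic acid at this position, or an N-methyl carboxamide that keeps the carbonyl carbon on the ring, would help show which feature tracks with the read-out.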